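This account rests on a few compounds, and the source may have more. Where it says the series, first, only, none or still open, it means among the compounds named here.

Compound 1 `Cc1cccc(C)c1Oc1cc(Nc2ccc(C#N)cc2)[nH]c(=O)c1Cl` is the reference point of this small set. Going by the values given here, in an ADME assay on MT4 cells (Homo sapiens) for cytotoxicity, read by MTT assay, with a stated time of 5 days (a higher number here means that more compound is tolerated, a lower number that less compound is tolerated), compound 1 gives 29000 nM, the lowest of the three numbers so far. Compound 2 `Cc1cccc(C)c1Oc1cc(Nc2ccc(C#N)cc2)[nH]c(=O)c1` gives 36000 nM in this assay, and compound 3 `Cc1cccc(C)c1Oc1cc(Nc2ccc(C#N)cc2)[nH]c(=O)c1Br` gives 63000 nM. The step of a 1.2-fold higher number from compound 1 to compound 2 (0.09 log units; within the scatter) and the step of a 1.8-fold higher number from compound 2 to compound 3 (0.24 log units; within the scatter) stay within the scatter; only a 2.2-fold higher number from compound 1 to compound 3 (0.34 log units; beyond the scatter) lies beyond it, and all three steps concern the halogen on the core, not the group on the oxygen on the aromatic ring. Compound 4 `Cc1cc(C)cc(Oc2cc(Nc3ccc(C#N)cc3)[nH]c(=O)c2Cl)c1` differs from compound 1 by 3,5-dimethylphenyl in place of 2,6-dimethylphenyl on an oxygen on an aromatic ring. Among the compounds with values here, no measured step touches this part of the molecule, so nothing beyond the scatter is expected in this assay. Compound 4 is therefore estimated at 30000 nM, with a range from 13000 nM to 70000 nM, which means an expected step of a 1.0-fold higher number from compound 1 to compound 4 (0.01 log units; within the scatter).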

Compound 4, half-maximal cytotoxic concentration: 21000 nM
The estimate for compound 4 lay 1.4-fold (0.15 log units) above the measured number; the measured number falls inside the stated range.
By their numbers in this assay, from the lowest: compounds 4, 1, 2 and 3 (each within the scatter of the next, the first and the last beyond it).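

Going by these compounds alone, at this position on the oxygen, the first reading in this assay is a 1.4-fold lower number from compound 1 to compound 4 (0.14 log units; within the scatter), so 3,5-dimethylphenyl in place of 2,6-dimethylphenyl, with the same atoms joined differently, moves the number no further than the scatter. The group on the oxygen therefore joins the halogen on the core as a place where a single change has so far stayed small, apart from the step between bromo and chloro. No measurement bears on why this step is small.

Open, going by these compounds, is whether an unsubstituted phenyl, a methoxy group or a carboxylic acid on this ring would stay as close to compound 1. Also open, on these data alone, is whether 3,5-dimethylphenyl would behave alike on the cores of compound 2 and compound 3.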